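This account rests on a few compounds, and the source may have more. Where it says the series, first, only, none or still open, it means among the compounds named here.

Compound 2, `C[C@H](NC(=O)c1cnnn1Cc1ccc(C(F)(F)F)cc1)c1ccc(C(=O)O)cc1`, carries the shared core with a hydrogen on the aromatic carbon that is the point of interest here. In a functional assay on CHO cells for antagonist activity at prostaglandin E2 receptor EP4 subtype (Homo sapiens), read by calcium flux, with a stated time of 15 min (a higher number here means a weaker inhibitor, a lower number a stronger inhibitor), compound 2 returns only a limit of the assay, > 10000 nM, not a number. Compound 1, `Cc1c(C(=O)N[C@@H](C)c2ccc(C(=O)O)cc2)nnn1Cc1ccc(C(F)(F)F)cc1`, with a methyl on that same aromatic carbon, likewise gives compound 1 only a limit, > 10000 nM. Compound 3, `C[C@H](NC(=O)c1c(-c2ccccc2)nnn1CCOc1ccc(C(F)(F)F)cc1)c1ccc(C(=O)O)cc1`, differs in two places at once, a phenyl on the core and an ethoxy linker to the trifluoromethylphenyl group, and compound 3 gives a measured half-maximal inhibitory concentration of 49.1 nM. Among the measured compounds shown here, compound 2 therefore stands at the weak end of what has been measured, sitting on (the limit of > 10000 nM in this assay, at which 2 of the 3 values shown sit), and no single-point step between measured compounds exists to say how much a group on that aromatic carbon is worth.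

Compound 4, `C[C@H](NC(=O)c1c(C2CCC2)nnn1Cc1ccc(C(F)(F)F)cc1)c1ccc(C(=O)O)cc1`, is compound 2 with cyclobutyl in place of hydrogen on an aromatic carbon, keeping the 4-(trifluoromethyl)benzyl group in place. Compound 3 shows that a larger group on the core can go with a numerical value, but its changed linker leaves that reading uncertain. The expected step from compound 2 to compound 4 is an at least 4.0-fold lower number from compound 2 to compound 4 (0.60 log units; beyond the scatter), a gain beyond the usual scatter but without confidence. Compound 4 is estimated at 2500 nM, within a range from 300 nM to 15000 nM.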

Compound 4, half-maximal inhibitory concentration: 75.3 nM
Estimate against measurement, compound 4: 33-fold (1.52 log units) above; the whole stated range lies above it.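

In this assay, cyclobutyl in place of hydrogen on an aromatic carbon gives an at least 130-fold lower number from compound 2 to compound 4 (2.12 log units; beyond the scatter), so this single change, with the 4-(trifluoromethyl)benzyl group kept in place, carries the compound from a limit of the assay to a measured value, something compound 3 could not show with its two changes at once. Not every group on this carbon has that outcome: compound 1, with a methyl there, gives only a limit of the assay, > 10000 nM. The true size of the cyclobutyl step stays unknown and only its lower bound can be stated, because compound 2 gives no number: the limit of > 10000 nM in this assay, at which 2 of the 4 values shown sit.

What the compounds shown leave open is whether the gain follows the ring itself or simply the number of carbons on this position, a question that a cyclopropyl ring, an isopropyl group or a cyclopentyl ring at the same carbon would address. They also leave open how an amine or a methoxy group on that carbon would read in this assay.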